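Switching the triazole substituent on a second core

This account rests on a few compounds, and the source may have more. Where it says the series, first, only, none or still open, it means among the compounds named here.

The study covers two cores carrying a triazole-linked aryl group, tested in a functional assay on SW480 cells (Homo sapiens) for cytotoxicity, read by MTT assay, with a stated time of 4 days; on this read-out higher numbers stand for weaker inhibition and lower numbers for stronger inhibition. Compound 1 `C=C1C(=O)[C@]23C[C@@]1(O)CC[C@H]2c1ccc(O)c(C)c1[C@@H]3Cn1cc(-c2ccccn2)nn1` gives 410 nM. Compound 3 `C=C1C(=O)[C@]23C[C@@]1(O)CC[C@H]2c1ccc(O)c(C)c1[C@@H]3Cn1cc(-c2ccc(C(F)(F)F)cc2)nn1` gives 370 nM. The change between them, (4-(trifluoromethyl)phenyl in place of pyridin-2-yl on an aromatic carbon), produced a 1.1-fold lower number from compound 1 to compound 3 (0.04 log units; within the scatter). Compound 2 `Cc1c(O)ccc2c1[C@H](Cn1cc(-c3ccccn3)nn1)[C@@]13CC(=O)[C@@](C)(CC[C@@H]21)C3` belongs to the second core; how the two cores differ is not broken down here. In this assay compound 2 reaches only the limit > 20000 nM, as shown by the limit of > 20000 nM in this assay, at which 1 of the 3 values shown sits. Compound 4 `Cc1c(O)ccc2c1[C@H](Cn1cc(-c3ccc(C(F)(F)F)cc3)nn1)[C@@]13CC(=O)[C@@](C)(CC[C@@H]21)C3` is the counterpart of compound 3 on the core of compound 2, made by the same change, (4-(trifluoromethyl)phenyl in place of pyridin-2-yl on an aromatic carbon). Since compound 1 and compound 3 sit within the scatter of each other after this change, the step from compound 2 to compound 4 is expected to be of the same small size, a number no higher from compound 2 to compound 4 (the limit leaves the size open). Compound 4 is therefore estimated at 20000 nM in this assay, most likely again reported only as a limit, with a plausible range from 8000 nM to 50000 nM.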

Compound 4, half-maximal inhibitory concentration: > 20000 nM
Compound 4: a limit, no number; the forecaster's own chance of this, stated with the estimate: 80%; the middle value sits exactly at the limit.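

No step can be read from compound 2 to compound 4, because each of the two is reported only as a limit and not as a number: the limit of > 20000 nM in this assay, at which 2 of the 4 values shown sit. The compounds shown leave open how far 4-(trifluoromethyl)phenyl and pyridin-2-yl differ on the core of compound 2, where neither compound has a number.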